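From a furan-3-yl amide to a 1,3-thiazol-5-yl amide

The compounds below may be only part of what the source reports. "The series", "measured", "known", "first", "only" and "open" are said of these compounds alone.

- compound 1 `CCCCCCCCCCCC[C@@H](O)[C@H]1CC[C@H]([C@H](O)CCCCCCCCCCNC(=O)c2cccs2)O1` gives 2000 nM
- compound 2 `CCCCCCCCCCCC[C@@H](O)[C@H]1CC[C@H]([C@H](O)CCCCCCCCCCNC(=O)c2ccoc2)O1` gives 79400 nM

In a functional assay on HCC 2998 cells (Homo sapiens) for inhibition, read by colorimetric assay and sulforhodamine B assay, with a stated time of 48 h (on this read-out higher numbers stand for weaker inhibition of growth and lower numbers for stronger inhibition of growth), compound 2 has the higher of the two numbers. Compound 3 `CCCCCCCCCCCC[C@@H](O)[C@H]1CC[C@H]([C@H](O)CCCCCCCCCCNC(=O)c2cncs2)O1` differs from it in one group, 1,3-thiazol-5-yl in place of furan-3-yl on a carbonyl carbon is the full count. Within the data shown here, only one measured step bears on this, a swap at the same carbonyl carbon, and it is large: a 40-fold higher number from compound 1 to compound 2 (1.60 log units; beyond the scatter) is that step. Compound 1 carries thiophen-2-yl, which also contains sulfur, so a move toward a lower number is expected in this assay but probably not the full distance. The estimated step is a 6.6-fold lower number from compound 2 to compound 3 (0.82 log units; beyond the scatter) in size. For compound 3 the estimated value is 12000 nM, within a range from 2500 nM to 60000 nM.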

Compound 3, concentration for 50% growth inhibition: 100000 nM
Compound 3: the middle estimate sits 8.3-fold (0.92 log units) below what was measured; the measured number lies above the stated range.
By their numbers in this assay, from the lowest: compound 1; then compounds 2 and 3 (each within the scatter of the next).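

Sulfur in the ring on the carbonyl carbon is not enough on its own: compound 3 carries it in 1,3-thiazol-5-yl, yet in this assay the change shows a 1.3-fold higher number from compound 2 to compound 3 (0.10 log units; within the scatter) and leaves it level with the furan-3-yl amide. Set against the thiophen-2-yl amide, the same ring gives a 50-fold higher number from compound 1 to compound 3 (1.70 log units; beyond the scatter) and so leaves compound 1 alone among these three. Nothing measured here accounts for this gap.

The compounds shown leave open whether a thiophen-3-yl or phenyl amide would fall with compound 1 or with compounds 2 and 3.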